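The compounds below may be only part of what the source reports. "The series", "measured", "known", "first", "only" and "open" are said of these compounds alone.

Compound 1 `Cn1c2cnc1OCCCCCCCCCOc1ccccc1-2` and compound 2 `C=CCCCCOc1ccccc1-c1cnc(OCCC=C)n1C` were both measured in a functional assay on PC-3 cells (Homo sapiens) for inhibition, read by colorimetric assay and MTT assay, with a stated time of 72 h; a lower number here means a stronger inhibitor, a higher number a weaker inhibitor. In this assay compound 1 gives 61000 nM, while compound 2 gives 19000 nM. Compound 2 therefore stands at the lower of the two numbers, and the gap to compound 1 lies beyond the scatter. Within the data shown here, no pair of measured compounds differing in a single place is available, so the weight of a small change cannot be read off from the data. Compound 3 `C=CCCCCOc1ccc(C)cc1-c1cnc(OCCC=C)n1C` differs from compound 2 in one place: methyl in place of hydrogen on an aromatic carbon. Among the measured compounds shown here, with only two measured compounds and no comparable single-site change, such a small addition is expected to move the number little, in no certain direction, and not beyond the scatter. The expected step is a 1.2-fold lower number from compound 2 to compound 3 (0.07 log units; within the scatter). In this assay compound 3 is expected to give about 16000 nM, within a range of 6000 nM to 45000 nM.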

Compound 3, half-maximal inhibitory concentration: 59000 nM
Compound 3: the middle estimate sits 3.7-fold (0.57 log units) below what was measured; measured number above the stated range.
By their numbers in this assay, from the lowest: compound 2; then compounds 3 and 1 (each within the scatter of the next).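

In this assay, among these compounds, methyl in place of hydrogen on the aromatic carbon para to the (hex-5-en-1-yl)oxy group gives a 3.1-fold higher number from compound 2 to compound 3 (0.49 log units; beyond the scatter) and thus provides the first single-place comparison. It shows that this position is not indifferent to the change: one added carbon moves the number beyond the scatter, towards weaker inhibition. Nothing shown here gives a measured reason for this rise.

The compounds shown leave open whether the same carbon would respond in the same way to an ethyl group, a methoxy group, fluorine or an amine. They also leave open whether methyl on another carbon of this six-membered aromatic ring would raise the number as well, or whether the step would carry over to the core of compound 1.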